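The source may report more compounds than this note shows. Statements on the series, on what has been measured and on what is new or still open speak of the compounds shown alone.

Of the compounds shown here, two have so far been measured in an assay on isolated protein for inhibition of thymidine kinase, cytosolic (Rattus norvegicus); on this read-out higher numbers stand for weaker inhibition and lower numbers for stronger inhibition. Compound 1 `C/C=C/c1cn([C@H]2C[C@H](O)[C@@H](CO)O2)c(=O)[nH]c1=O` gives 15500000 nM in this assay, a very weak result. Compound 2 `CCCCCCNCC1OC(n2cc(C)c(=O)[nH]c2=O)CC1O` gives 35000 nM in this assay, which is the lowest of the two numbers; its gap to compound 1 lies far beyond the usual scatter, so compound 2 is clearly the stronger inhibitor of the pair.

Compound 3 `Cc1cn(C2CC(O)C(CSCCO)O2)c(=O)[nH]c1=O` has not been measured yet. It differs from compound 2 in a single place: (2-hydroxyethyl)sulfanyl in place of hexylamino on a saturated chain carbon bound to a saturated ring carbon. For the measured compounds named here, no measured pair of compounds shows a change of this kind, so the size of its effect cannot be read from the numbers in hand; the only anchor is compound 2 with its value of 35000 nM in this assay. The expectation is a step toward weaker inhibition that goes beyond the scatter, of the size a 4.3-fold higher number from compound 2 to compound 3 (0.63 log units; beyond the scatter). On that basis compound 3 is estimated to give 150000 nM in this assay, with a likely range from 30000 nM to 1000000 nM.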

Compound 3, inhibition constant: 820000 nM
The estimate for compound 3 lay 5.5-fold (0.74 log units) below the measured number, within the range that was stated.
By their numbers in this assay, from the lowest: compound 2; then compound 3; then compound 1.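

For the compounds shown here, the swap at this saturated chain carbon bound to a saturated ring carbon gives the first step between two compounds that differ in one place: in this assay, putting (2-hydroxyethyl)sulfanyl in place of hexylamino is a 23-fold higher number from compound 2 to compound 3 (1.37 log units; beyond the scatter), a large move toward weaker inhibition. So this position is not indifferent to what it carries, and here the hexylamino group goes with the stronger inhibition. Going by these compounds alone, the single step changes several things at once, since the group entering is shorter by the heavy-atom count and brings sulfur and oxygen where the group leaving has nitrogen, and nothing measured here explains the loss or says which of these differences matters.

Hexylsulfanyl and (2-hydroxyethyl)amino groups at this place would pull apart the atom attached to the chain carbon and the rest of the chain, and how either one compares with compound 2 and compound 3 remains open. Also open, from the compounds shown here alone, is whether an amine with a longer chain than hexylamino would take the number lower still, or whether hexylamino is already close to the best length.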